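From a Thiosemicarbazide to a Thiophene Hydrazone

The source may report more compounds than this note shows. Statements on the series, on what has been measured and on what is new or still open speak of the compounds shown alone.

Measured compounds:
Compound 1, `CC1=CC[C@H](C(C)(C)N=C=S)CC1`: in a functional assay on NCI/ADR-RES cells (Homo sapiens) for inhibition, read by sulforhodamine B assay, with a stated time of 48 h (a lower number here means a stronger inhibitor of growth, a higher number a weaker inhibitor of growth), compound 1 gives > 100000 nM, which is a limit of the assay.
Compound 2, `CC1=CC[C@H](C(C)(C)NC(=S)NN)CC1`: compound 2 gives 39300 nM.
Compound 3, `CC1=CC[C@H](C(C)(C)NC(=S)N/N=C/c2ccccc2O)CC1`: compound 3 gives 3700 nM.

Compound 2 stands at the highest of the two full numbers; compound 3 sits well below it, beyond the scatter. Among the measured compounds shown here, the only measured step, an at least 2.5-fold lower number from compound 1 to compound 2 (0.40 log units; beyond the scatter), starts at a limit of > 100000 nM in this assay, at which 1 of the 3 values shown sits, and concerns a different change, so it bears little on what follows.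

Compound 4, `CC1=CC[C@H](C(C)(C)NC(=S)N/N=C/c2cccs2)CC1`, differs from compound 2 by a group of 7 heavy atoms (5 carbon, 1 nitrogen, 1 sulfur; one five-membered aromatic ring with 1 hetero atom) in place of one nitrogen atom, on an amide-type nitrogen. For the measured compounds named here, no measured step covers this change; the nearest guide is what the values of compound 2 and compound 3 show, where a related hydrazone gives the much lower number. A drop of similar size is therefore expected, giving compound 4 an estimated 6000 nM, expected between 2000 nM and 20000 nM. The expected change is a 6.6-fold lower number from compound 2 to compound 4 (0.82 log units; beyond the scatter).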

Compound 4, concentration for 50% growth inhibition: 13600 nM
Compound 4: middle estimate off by 2.3-fold (0.36 log units), on the low side; the measured number falls inside the stated range.
By their numbers in this assay, from the lowest: compound 3; then compound 4; then compound 2. At a limit, above all of these: compound 1.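

The lower number does not depend on 2-hydroxyphenyl alone, since a thiophene-bearing hydrazone on the amide-type nitrogen also gives a 2.9-fold lower number from compound 2 to compound 4 (0.46 log units; beyond the scatter) in this assay. The choice of ring still counts, as thiophen-2-yl in place of 2-hydroxyphenyl gives a 3.7-fold higher number from compound 3 to compound 4 (0.57 log units; beyond the scatter) and gives back part of that gain. Nothing measured here accounts for the gap between these two rings.

Still open, as far as these compounds go, is whether the hydroxyl or the ring itself matters more, which plain phenyl on the same carbon could help settle. A furan-2-yl or pyridin-2-yl ring there also remains untested in the compounds shown.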